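Amide nitrogen change from compound 1 to compound 3

The source may hold more compounds than are shown below. What is called first, only, known or untested is meant among the compounds shown, and "the series" means these compounds.

Compound 1 `O=C(/C=C1\CCc2ccc(F)cc21)NCC1CC1` stands highest of the two numbers shown in a functional assay on the whole organism with Rattus norvegicus as the target, at a dose of 20 mg/kg by the oral route (a lower number here means less inhibition, a higher number more inhibition at the dose given (going by the name of the read-out)), at 21%. Compound 2 `Cc1cccc2c1CC/C2=C\C(N)=O` gives 13% in this assay, a number within the scatter of compound 1, so no order between the two is claimed. Compound 3 `CCN(C)C(=O)/C=C1\CCc2ccc(F)cc21` differs from compound 1 by ethyl(methyl)amino in place of (cyclopropylmethyl)amino on a carbonyl carbon. Going by the values given here, no measured pair shows what this change does, and the two known values offer no guide. The step from compound 1 to compound 3 is expected to be small, a number 4 percentage points lower from compound 1 to compound 3 (within the scatter), with no direction beyond the scatter. Compound 3 is estimated at 17%, between 5% and 32%.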

Compound 3, a percentage reported as inhibition, in the whole organism at one dose (the size of the read-out at that dose, not a potency): 44%
The estimate for compound 3 lay 27 percentage points below the measured number; the measured number lies above the stated range.
By their numbers in this assay, from the lowest: compounds 2 and 1 (each within the scatter of the next); then compound 3.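

In this assay, going by these compounds alone, this position on the carbonyl carbon responds to the amine carried there: ethyl(methyl)amino in place of (cyclopropylmethyl)amino gives a number 23 percentage points higher from compound 1 to compound 3 (beyond the scatter) and this is the only step so far. The change removes the hydrogen-bond donor and the three-membered ring together, so the step cannot be assigned to either one alone. No available evidence bears on the origin of this step.

Going by these compounds, whether the ring or the amide hydrogen matters remains open. (Cyclopropylmethyl)(methyl)amino, which keeps the ring without the amide hydrogen, and ethylamino, which keeps the amide hydrogen without the ring, would separate the two.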